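Swapping a small ring for a short alkyne on the ether

A few compounds are considered here, and "the series" means these few. Any claim that something is new, unique, unknown or untested is made for them only; others in the source may bear on it.

Of the compounds shown here, two built on one shared core have been tested in an assay on cells with melanin-concentrating hormone receptor 1 (Homo sapiens) as the target, read by radioligand binding; on this read-out higher numbers stand for weaker inhibition and lower numbers for stronger inhibition. Compound 1 `COCCOCCOc1cccc2ccc(N)nc12` reaches only a limit of the assay, > 2000 nM. Going by the values given here, compound 2 `CC1CC1COc1cccc2ccc(N)nc12` gives 1640 nM, the only definite number so far. Among the compounds with values here, the one measured step, an at least 1.2-fold lower number from compound 1 to compound 2 (0.08 log units; that floor lies within the scatter), has a floor within the scatter (the limit of > 2000 nM in this assay, at which 1 of the 2 values shown sits). Compound 3 `CCC#CCOc1cccc2ccc(N)nc12` differs from compound 2 by but-1-yn-1-yl in place of 2-methylcyclopropyl on a saturated chain carbon bound to an oxygen on an aromatic ring. Within the data shown here, no measured step covers a ring-to-triple-bond swap at this place, so no step beyond the scatter is expected, a 1.1-fold lower number from compound 2 to compound 3 (0.04 log units; within the scatter). Compound 3 is estimated at 1500 nM, between 600 nM and 4000 nM.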

Compound 3, half-maximal inhibitory concentration: > 2000 nM
Compound 3: only a limit was reported; the forecaster's own chance of this, stated with the estimate: 35%; at least 1.3-fold (0.12 log units) between middle value and limit.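

Putting but-1-yn-1-yl in place of 2-methylcyclopropyl on the saturated chain carbon bound to an oxygen on an aromatic ring gives an at least 1.2-fold higher number from compound 2 to compound 3 (0.08 log units; that floor lies within the scatter). Going by these compounds alone, this open chain with a triple bond therefore brings no measurable gain over the small ring, and compound 2 remains the only compound with a definite number. The step between compound 1 and compound 3 cannot be read, because both values are limits: the limit of > 2000 nM in this assay, at which 2 of the 3 values shown sit.

On these data alone, the true size of the step to compound 3 remains open. So does whether an amine or a carboxylic acid at this place would give a clearly lower number.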